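The source may report more compounds than this note shows. Statements on the series, on what has been measured and on what is new or still open speak of the compounds shown alone.

Working notes on the series. Three compounds share a core and differ only in the aryl group on the carbonyl carbon. Compound 1 `COc1cc(C(=O)/C=C\Nc2ccc(-c3nc4cc(OC)c(OC)c(OC)c4s3)cc2)c(Br)c(OC)c1OC` gives 13600 nM in a functional assay on A549 cells (Homo sapiens) for antiproliferative activity, read by sulforhodamine B assay, with a stated time of 48 h; a lower number here means a stronger inhibitor, a higher number a weaker inhibitor. Compound 2 `COc1ccc(C(=O)/C=C\Nc2ccc(-c3nc4cc(OC)c(OC)c(OC)c4s3)cc2)cc1F` gives 15500 nM in this assay, and compound 3 `COc1ccc(C(=O)/C=C\Nc2ccc(-c3nc4cc(OC)c(OC)c(OC)c4s3)cc2)cc1O` gives 23000 nM in this assay. Going by the values given here, the only single-point step measured so far, a 1.5-fold higher number from compound 2 to compound 3 (0.17 log units; within the scatter), shows no movement of note. Compound 3 thus holds the highest of the three numbers shown, but its gaps to compound 2 and to compound 1 both lie within the scatter, so no order among the three can be stated.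

Compound 4 `COc1cc(C(=O)/C=C\Nc2ccc(-c3nc4cc(OC)c(OC)c(OC)c4s3)cc2)cc(OC)c1OC` is not yet measured. Relative to compound 3 the change is 3,4,5-trimethoxyphenyl in place of 3-hydroxy-4-methoxyphenyl on a carbonyl carbon. Among the compounds with values here, no measured step covers an exchange of the whole aryl group; the one step available concerns a single substituent and is within the scatter. Compound 1 carries a related aryl group and its value 13600 nM sits within the scatter of the others. The expected step is therefore a 2.1-fold lower number from compound 3 to compound 4 (0.32 log units; beyond the scatter), not clearly beyond the scatter, with the wide range reflecting the lack of a directly comparable step. Compound 4 is estimated at 11000 nM in this assay, with a range from 2500 nM to 40000 nM.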

Compound 4, half-maximal inhibitory concentration: 15500 nM
For compound 4 the middle estimate is 1.4-fold (0.15 log units) below the measured one; low and high end bracket the measured number.
By their numbers in this assay, from the lowest: compounds 1, 2, 4 and 3 (each within the scatter of the next).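

In this assay, 3,4,5-trimethoxyphenyl in place of 3-hydroxy-4-methoxyphenyl on the carbonyl carbon gives a 1.5-fold lower number from compound 3 to compound 4 (0.17 log units; within the scatter), so this exchange of the whole aryl group, which also removes the hydrogen-bond donor of the leaving group, shows no movement beyond the scatter. The same group in place of 3-fluoro-4-methoxyphenyl gives no change at the digits printed from compound 2 to compound 4 (within the scatter), and hydrogen in place of bromo on an aromatic carbon gives a 1.1-fold higher number from compound 1 to compound 4 (0.06 log units; within the scatter), so the bromo group of compound 1 also makes no readable difference. Where the earlier compounds offered only a single-substituent step, these steps extend the same flat picture to aryl groups differing in several substituents, though only for the four compounds listed here.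

No supporting measurement bears on why these numbers stay so close. As far as these compounds go, it remains open whether a dimethylamino group or a carboxylic acid on this aryl ring, or a saturated cyclohexyl group in place of the ring, would move the number beyond the scatter in either direction.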